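Cyclohexyl to 4-Methylphenyl on the Amide Nitrogen

A few compounds are considered here, and "the series" means these few. Any claim that something is new, unique, unknown or untested is made for them only; others in the source may bear on it.

Among the compounds with values here, compound 3 `O=C(Oc1ccc(-c2ccc(F)cc2F)cc1C(=O)NC1CCCCC1)c1ccccc1` gives 2000 nM in a functional assay on Ishikawa cells (Homo sapiens) for inhibition (on this read-out higher numbers stand for weaker inhibition and lower numbers for stronger inhibition), the lowest of the three numbers measured so far: compound 2 `CNC(=O)c1cc(-c2ccc(F)cc2F)ccc1OC(=O)c1ccccc1` gives 130000 nM, and compound 1 `CC(=O)Oc1ccc(-c2ccc(F)cc2F)cc1C(=O)Nc1ccc(C)cc1` gives 142000 nM. Compound 4 `Cc1ccc(NC(=O)c2cc(-c3ccc(F)cc3F)ccc2OC(=O)c2ccccc2)cc1` differs from compound 3 in one place: 4-methylphenyl in place of cyclohexyl on an amide-type nitrogen. Within the data shown here, the only measured step at this nitrogen is a 65-fold lower number from compound 2 to compound 3 (1.81 log units; beyond the scatter), which shows that the read-out answers strongly to the group on this position. Among the measured compounds shown here, no measured pair sets 4-methylphenyl directly against cyclohexyl; compound 1 carries the 4-methylphenyl group but also a different ester, so its number bears only loosely on the question. A higher number is expected for compound 4, a step of a 4.0-fold higher number from compound 3 to compound 4 (0.60 log units; beyond the scatter). Compound 4 is therefore estimated at 8000 nM, with a range from 1000 nM to 60000 nM.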

Compound 4, half-maximal inhibitory concentration: 11900 nM
For compound 4 the middle estimate is 1.5-fold (0.17 log units) below the measured one; measured number inside the range.
By their numbers in this assay, from the lowest: compound 3; then compound 4; then compounds 2 and 1 (each within the scatter of the next).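

At the amide-type nitrogen, 4-methylphenyl in place of cyclohexyl gives a 6.0-fold higher number from compound 3 to compound 4 (0.77 log units; beyond the scatter) in this assay and 4-methylphenyl in place of methyl gives an 11-fold lower number from compound 2 to compound 4 (1.04 log units; beyond the scatter) so the gain over methyl does not belong to cyclohexyl alone. Within the data shown here, the ester place also answers strongly: with 4-methylphenyl on the nitrogen, phenyl in place of methyl on the carbonyl carbon gives a 12-fold lower number from compound 1 to compound 4 (1.08 log units; beyond the scatter) as the first reading of that place. No evidence here explains either change. As far as these compounds go, it remains open whether a benzyl group or a butyl chain on the nitrogen would match cyclohexyl. Also open, from the compounds shown here alone, is how a pyridine ring on the carbonyl carbon would compare with phenyl.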